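Dimethoxyphenyl for Benzodioxinyl: Expected Cytotoxicity of Compound 4

The source may hold more compounds than are shown below. What is called first, only, known or untested is meant among the compounds shown, and "the series" means these compounds.

Compound 1 `CN(Cc1ccc2c(c1)OCCO2)c1cc(=O)c2cc(C(F)(F)F)cc([N+](=O)[O-])c2s1` and compound 2 `COc1ccc(CN(C)c2cc(=O)c3cc(C(F)(F)F)cc([N+](=O)[O-])c3s2)cc1OC` share one core; compound 3 `O=c1nc(NCc2ccc3c(c2)OCCO3)oc2c([N+](=O)[O-])cc(C(F)(F)F)cc12` rests on another, and the difference between the two cores is not broken down here. Compound 4 `COc1ccc(CNc2nc(=O)c3cc(C(F)(F)F)cc([N+](=O)[O-])c3o2)cc1OC` is the partner of compound 3 that has not been measured. In an ADME assay on Vero cells (Chlorocebus sabaeus) for cytotoxicity, read by MTT assay, with a stated time of 48 h (on this read-out higher numbers stand for weaker inhibition and lower numbers for stronger inhibition), compound 1 gives only a limit of the assay, > 64 ug/mL. In this assay compound 2 likewise gives only a limit, > 64 ug/mL. Compound 3 alone gives a number, 25.3 ug/mL. The change 3,4-dimethoxyphenyl in place of 2,3-dihydro-1,4-benzodioxin-6-yl on a saturated chain carbon bound to a nitrogen on an aromatic ring produces a step that the two limits leave unreadable from compound 1 to compound 2, since two of the three values sit at the limit of > 64 ug/mL in this assay, at which 2 of the 3 values shown sit. The same change, (3,4-dimethoxyphenyl in place of 2,3-dihydro-1,4-benzodioxin-6-yl on a saturated chain carbon bound to a nitrogen on an aromatic ring), leads to compound 4. Because a step that the two limits leave unreadable from compound 1 to compound 2 carries no readable size, no direction is set, and the expected step is a 1.0-fold lower number from compound 3 to compound 4 (0.01 log units; within the scatter). Compound 4 is estimated at 25 ug/mL, between 12 ug/mL and 64 ug/mL.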

Compound 4, half-maximal inhibitory concentration: 29.2 ug/mL
Estimate against measurement, compound 4: 1.2-fold (0.07 log units) below; the measured number falls inside the stated range.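

In this assay 3,4-dimethoxyphenyl in place of 2,3-dihydro-1,4-benzodioxin-6-yl produces a 1.2-fold higher number from compound 3 to compound 4 (0.06 log units; within the scatter) and so leaves the read-out on this core unchanged within the scatter. This does not show that the change behaves alike on both cores, since the step from compound 1 to compound 2 cannot be read: the limit of > 64 ug/mL in this assay, at which 2 of the 4 values shown sit. The series therefore offers one readable instance of this change, not a demonstrated transfer from one core to another.

On these data alone, what remains open is how plain phenyl or a pyridine would read in this assay at this place, on a saturated chain carbon bound to a nitrogen on an aromatic ring. Also open, as far as these compounds go, is whether a carboxylic acid or a longer chain there would move the number beyond the scatter.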